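The source may report more compounds than this note shows. Statements on the series, on what has been measured and on what is new or still open speak of the compounds shown alone.

Compound 1, `CN(C)CCn1cnnc1-c1cc(Oc2ccc(NC(=O)N/N=C/c3cc(Br)c(O)c(Br)c3)cc2F)ccn1`, and compound 2, `COc1ccc(/C=N/NC(=O)Nc2ccc(Oc3ccnc(-c4nncn4CCN(C)C)c3)c(F)c2)cc1O`, share a core and differ only in the aryl group attached to a carbon with a double bond to nitrogen. In a functional assay on U-87MG ATCC cells (Homo sapiens) for cytotoxicity, read by MTT assay, with a stated time of 72 h (a lower number here means a stronger inhibitor, a higher number a weaker inhibitor), compound 1 gives only a limit, > 100000 nM. In this assay compound 2 likewise gives only a limit, > 100000 nM. The step that the two limits leave unreadable from compound 1 to compound 2 therefore has no readable size because the limit of > 100000 nM in this assay, at which 2 of the 2 values shown sit, holds both values. Compound 2 thus stands at the limit, with no number of its own to compare against.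

Compound 3, `CN(C)CCn1cnnc1-c1cc(Oc2ccc(NC(=O)N/N=C/c3ccc(F)cc3Cl)cc2F)ccn1`, differs from compound 2 by 2-chloro-4-fluorophenyl in place of 3-hydroxy-4-methoxyphenyl on a carbon with a double bond to nitrogen. Within the data shown here, no measured step bears on this change: the only step measured, from compound 1 to compound 2, is unreadable, and no other pair exchanges this group. What can be expected for compound 3 therefore rests only on where compound 2 stands, and compound 3 is expected to remain near the limit, with an expected step of a number no higher from compound 2 to compound 3 (the limit leaves the size open) that carries no readable size. Compound 3 is estimated at 100000 nM, within a range from 30000 nM to 300000 nM.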

Compound 3, half-maximal inhibitory concentration: 1210 nM
The estimate for compound 3 lay 83-fold (1.92 log units) above the measured number; the whole stated range lies above it.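

In this assay, replacing the aryl group gives an at least 82-fold lower number from compound 2 to compound 3 (1.91 log units; beyond the scatter), and replacing the other aryl group gives an at least 82-fold lower number from compound 1 to compound 3 (1.91 log units; beyond the scatter). This shows that the group on a carbon with a double bond to nitrogen can shift the read-out strongly with the rest of the molecule unchanged, which the earlier pair could not show, since neither of its values is more than a limit. Halogens alone do not account for the shift: compound 1 carries two bromines and remains at its limit, while compound 3 carries chlorine and fluorine and no hydroxyl, and both compounds at the limit carry a hydroxyl, so the pattern rests on only these compounds, and the full size of both steps stays open because compound 1 and compound 2 give no number of their own: the limit of > 100000 nM in this assay, at which 2 of the 3 values shown sit.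

The compounds shown cannot separate the loss of the hydroxyl from the arrival of chlorine and fluorine. A plain phenyl, a phenyl carrying chlorine alone or fluorine alone, or the 2-chloro-4-fluorophenyl group with a hydroxyl added would be needed to tell which feature goes with the lower number.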